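The source may report more compounds than this note shows. Statements on the series, on what has been measured and on what is new or still open speak of the compounds shown alone.

Measured so far:
- compound 1 `Cc1ccc(-n2cc(-c3cccc(NS(=O)(=O)c4c[nH]c(=O)[nH]c4=O)c3)nn2)cc1`: 23100 nM
- compound 2 `O=c1[nH]cc(S(=O)(=O)Nc2cccc(-c3cn(-c4ccccc4F)nn3)c2)c(=O)[nH]1`: "not toxic" (no number reported)

In an ADME assay on L02 cells (Homo sapiens) for cytotoxicity, read by MTT assay, with a stated time of 24 h (on this read-out lower numbers stand for higher toxicity in this test and higher numbers for lower toxicity in this test), compound 1 gives 23100 nM. In this assay, among the measured compounds shown here, compound 2 is recorded as "not toxic" (no number reported), with no number attached, so compound 2 stands on no single figure and no step between the two measured compounds can be counted.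

Compound 3 `O=c1[nH]cc(S(=O)(=O)Nc2cccc(-c3cn(-c4cccc(Cl)c4)nn3)c2)c(=O)[nH]1` has not been measured. It differs from compound 2 by 3-chlorophenyl in place of 2-fluorophenyl on an aromatic nitrogen. For the measured compounds named here, with no counted step available, the expected change in this assay from compound 2 to compound 3 is none beyond the usual scatter; the shared core is kept and only the substituted phenyl on the aromatic nitrogen changes.

For compound 3 in this assay the expected value is 30000 nM, with a range from 10000 nM to 100000 nM, on the assumption that it sits near compound 1 at 23100 nM or, like compound 2, returns no number.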

Compound 3, half-maximal cytotoxic concentration: 8330 nM
The estimate for compound 3 lay 3.6-fold (0.56 log units) above the measured number, and the stated range ends above it.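

In this assay, the group on the aromatic nitrogen of the five-membered ring now shows a counted effect: 3-chlorophenyl in place of 4-methylphenyl gives a 2.8-fold lower number from compound 1 to compound 3 (0.44 log units; beyond the scatter), a shift towards higher toxicity in this test. Compound 3 also shows that this position can carry a substituted phenyl with a numeric result, while compound 2 remains recorded as "not toxic" without a number, so the change from 2-fluorophenyl to 3-chlorophenyl cannot be read as a step. Nothing on hand explains the shift.

These compounds do not separate the identity of the substituent from its place on the phenyl, since 4-methylphenyl and 3-chlorophenyl differ in both. On these data alone, how an amine or a carboxylic acid on that phenyl would read in this assay also stays open.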